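Adding a hydroxy group beside the nitro group

A few compounds are considered here, and "the series" means these few. Any claim that something is new, unique, unknown or untested is made for them only; others in the source may bear on it.

Measured compounds:
compound 1 `COc1cc(/C=C/C(=O)/C=C/C2=C(C)CCCC2(C)C)ccc1O` — 21300 nM
compound 2 `CC1=C(/C=C/C(=O)/C=C/c2cccc(C(F)(F)F)c2)C(C)(C)CCC1` — 7700 nM
compound 3 `CC1=C(/C=C/C(=O)/C=C/c2cccc([N+](=O)[O-])c2)C(C)(C)CCC1` — 10000 nM

In a functional assay on PC-3 cells (Homo sapiens) for cytotoxicity, read by MTT assay, with a stated time of 72 h (a lower number here means a stronger inhibitor, a higher number a weaker inhibitor), compound 3 gives 10000 nM, the second highest of the three numbers. Its nearest neighbour is compound 2, and the step of a 1.3-fold higher number from compound 2 to compound 3 (0.11 log units; within the scatter) lies within the scatter, so the two cannot be ranked. Compound 1 lies further away, beyond the scatter, with the highest number of the set.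

Compound 4 `CC1=C(/C=C/C(=O)/C=C/c2ccc(O)c([N+](=O)[O-])c2)C(C)(C)CCC1` differs from compound 3 by hydroxy in place of hydrogen on an aromatic carbon, placed on an aromatic carbon of a six-membered aromatic ring of carbon only, ortho to a nitro group and para to a large group. Within the data shown here, no measured step adds or removes a hydroxy on its own. Compound 1 also carries a hydroxy on its ring, together with a methoxy, and gives the highest number, but that pair of groups does not isolate the present change. The expected step from compound 3 is therefore small, a 1.3-fold higher number from compound 3 to compound 4 (0.11 log units; within the scatter), leaning slightly toward a higher number. For compound 4 the estimate in this assay is 13000 nM, ranging from 5000 nM to 35000 nM.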

Compound 4, half-maximal inhibitory concentration: > 50000 nM
Compound 4: no number, only a limit (the forecaster's own chance of this, stated with the estimate: 5%); at least 3.8-fold (0.58 log units) between middle value and limit.
By their numbers in this assay, from the lowest: compounds 2 and 3 (each within the scatter of the next); then compound 1. At a limit, above all of these: compound 4.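

In this assay compound 4 gives no number, only a limit: the limit of > 50000 nM in this assay, at which 1 of the 4 values shown sits.

Among these compounds, this is the first change in the set that adds a hydroxy and nothing else, and on a carbon ortho to a nitro group and para to a large group it is not a neutral swap, with a step of an at least 5.0-fold higher number from compound 3 to compound 4 (0.69 log units; beyond the scatter). A hydroxy on the ring does not settle the outcome by itself either, since the other group on that ring also counts, with a step of an at least 2.3-fold higher number from compound 1 to compound 4 (0.37 log units; beyond the scatter) for nitro in place of methoxy.

As far as these compounds go, how far each step really reaches stays open, and so does whether a hydroxy would do the same on a ring without the nitro group. Whether an amine or a fluorine on that same carbon would give a measurable number is also unanswered.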